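An Indole Returns to the Shared Core

This account rests on a few compounds, and the source may have more. Where it says the series, first, only, none or still open, it means among the compounds named here.

In a functional assay on HCT-116 cells (Homo sapiens) for inhibition, read by CCK-8 assay, with a stated time of 48 h (a higher number here means a weaker inhibitor, a lower number a stronger inhibitor), compound 1 `COc1cc(-c2ccnc3cc(-c4c[nH]c5ccccc45)nn23)cc(OC)c1OC` gives 35 nM. Compound 2 `COc1cc(-c2ccnc3cc(-c4cccc(C#N)c4)nn23)cc(OC)c1OC` gives only a limit, > 10000 nM. Compound 3 `COc1cc(-c2ccnc3cc(-c4ccc5c(ccn5C)c4)nn23)cc(OC)c1OC` changes the same place on the shared core: 1-methyl-1H-indol-5-yl in place of 3-cyanophenyl on an aromatic carbon. The measured step bearing on this is the one from 1H-indol-3-yl to 3-cyanophenyl, an at least 280-fold higher number from compound 1 to compound 2 (2.45 log units; beyond the scatter), which is large and beyond the scatter. Since an indole returns, though as 1-methyl-1H-indol-5-yl, a large step the opposite way is expected, an at least 120-fold lower number from compound 2 to compound 3 (2.09 log units; beyond the scatter). For compound 3 the estimate is 80 nM, with an expected range of 10 nM to 800 nM.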

Compound 3, half-maximal inhibitory concentration: 39 nM
Estimate against measurement, compound 3: 2.1-fold (0.31 log units) above, within the range that was stated.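

Compound 2 gives only a limit of the assay, > 10000 nM. Replacing its 3-cyanophenyl with 1-methyl-1H-indol-5-yl gives an at least 250-fold lower number from compound 2 to compound 3 (2.40 log units; beyond the scatter), so a second indole, attached differently, also stands far from that limit. Between the two indoles there is a 1.1-fold higher number from compound 1 to compound 3 (0.05 log units; within the scatter), which shows this position accepts either 1H-indol-3-yl or 1-methyl-1H-indol-5-yl without a change that can be read. Still open, going by these compounds, is whether an indole is needed at all, or whether an amine or a carboxylic acid in place of the nitrile on the phenyl ring would also serve.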